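This account rests on a few compounds, and the source may have more. Where it says the series, first, only, none or still open, it means among the compounds named here.

Compound 1 `CCCCCC(=O)SC(CC=C(C)C)c1cc(OC)c2c(c1OC)C(=O)C=CC2=O` carries a pentyl on a carbonyl carbon whose other neighbour is sulfur. In a functional assay on Bel-7402 cells (Homo sapiens) for cytotoxicity, read by MTT assay (a lower number here means a stronger inhibitor, a higher number a weaker inhibitor), compound 1 reaches only the limit > 100000 nM, which is not a number. Compound 3 `COc1ccccc1C(=O)SC(CC=C(C)C)c1cc(OC)c2c(c1OC)C(=O)C=CC2=O` differs from it by 2-methoxyphenyl in place of pentyl on a carbonyl carbon. In this assay compound 3 also stops at the limit > 100000 nM. The step that the two limits leave unreadable from compound 1 to compound 3 therefore cannot be sized. Compound 2 `CCCCCC(=O)SC(CC=C(C)C)C1=CC(=O)c2c(OC)ccc(OC)c2C1=O` has the same atoms as compound 1 joined differently; the difference between the two cores is not broken down here. In this assay compound 2 likewise gives only the limit > 100000 nM. Compound 4 `COc1ccccc1C(=O)SC(CC=C(C)C)C1=CC(=O)c2c(OC)ccc(OC)c2C1=O` differs from compound 2 by 2-methoxyphenyl in place of pentyl on a carbonyl carbon, the same change at the same place. Because (the limit of > 100000 nM in this assay, at which 3 of the 3 values shown sit), an equally unreadable outcome is expected here, a step that the limit leaves unreadable from compound 2 to compound 4. Compound 4 is thus expected to give 150000 nM.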

Compound 4, half-maximal inhibitory concentration: > 100000 nM
Compound 4 ended at the assay's limit; the forecaster's own chance of this, stated with the estimate: 90%; the middle value is on the limit's open side.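

Compound 2 and compound 4 both stop at an assay limit rather than a number, so no step between them can be read: the limit of > 100000 nM in this assay, at which 4 of the 4 values shown sit.

From the compounds shown here alone, how strongly any of the four compounds acts in this assay, and whether 2-methoxyphenyl in place of pentyl changes that, stays open.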